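This account rests on a few compounds, and the source may have more. Where it says the series, first, only, none or still open, it means among the compounds named here.

Of the compounds shown here, three sharing one core have been measured so far. Compound 1 `Cc1cc(O)c(C(=O)/C=C/c2ccc(F)cc2)c(-c2ccccc2)c1C(=O)/C=C/c1ccc(F)cc1` carries a plain phenyl group on the core; in a functional assay on HeLa cells (Homo sapiens) for cytotoxicity, read by MTT assay, with a stated time of 24 h (a lower number here means a stronger inhibitor, a higher number a weaker inhibitor), compound 1 gives 30000 nM. Compound 3 `Cc1cc(O)c(C(=O)/C=C/c2ccccc2)c(-c2ccc(Br)cc2)c1C(=O)/C=C/c1ccccc1` carries a 4-bromophenyl group instead and differs in its two arms as well; in this assay compound 3 gives 30000 nM, so compound 1 and compound 3 sit level at the digits reported, within the usual scatter. Compound 2 `COc1ccc(/C=C/C(=O)c2c(C)cc(O)c(C(=O)/C=C/c3ccc(OC)c(OC)c3)c2-c2ccccc2)cc1OC` is recorded in this assay as "not active" (no number reported), with no number given.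

Compound 4 `Cc1cc(O)c(C(=O)/C=C/c2ccc(F)cc2)c(-c2ccc(Br)cc2)c1C(=O)/C=C/c1ccc(F)cc1` is the next entry. Compared with compound 1 the change is bromo in place of hydrogen on an aromatic carbon, the same phenyl-to-4-bromophenyl exchange that compound 3 carries. For the measured compounds named here, no step between measured compounds isolates this change, yet compound 1 and compound 3 show the same digits with and without it. Compound 4 is therefore expected to show no step beyond the scatter, with no change at the digits printed from compound 1 to compound 4 (within the scatter). The estimate for compound 4 in this assay is 30000 nM, with a range from 12000 nM to 70000 nM.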

Compound 4, half-maximal inhibitory concentration: "not active" (no number reported)
Nothing numeric was reported for compound 4, and the estimate cannot be compared.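

For the compounds shown here, compound 4 is recorded without a number in this assay, so no step from compound 1 to compound 4 can be read. Going by these compounds, whether bromo in place of hydrogen on the shared core's phenyl group shifts the value stays open. Nothing shown here bears on this result.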